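Removing a methyl from the benzyl group of compound 2

A few compounds are considered here, and "the series" means these few. Any claim that something is new, unique, unknown or untested is made for them only; others in the source may bear on it.

Compound 1 `Cc1cc(Nc2cc(-c3ccccc3)[nH]n2)n2nc(SCc3ccc([N+](=O)[O-])cc3)nc2n1` gives 7980 nM in a functional assay on PC-9 cells (Homo sapiens) for inhibition, read by MTT assay, with a stated time of 72 h; on this read-out higher numbers stand for weaker inhibition and lower numbers for stronger inhibition. Compound 3 `CCCSc1nc2nc(C)cc(Nc3cc(-c4ccccc4)[nH]n3)n2n1` reaches only the limit of the assay, > 50000 nM. Among the measured compounds shown here, the one-place change between them, an at least 6.2-fold higher number from compound 1 to compound 3 (0.79 log units; beyond the scatter), is the only measured step in the set. Compound 2 `Cc1ccc(Cn2ccc(Nc3cc(C)nc4nc(SCc5ccc(Br)cc5)nn34)n2)cc1` likewise stands at the limit, > 50000 nM, and so the number is not known; it shares this limit with compound 3, as noted in the limit of > 50000 nM in this assay, at which 2 of the 3 values shown sit.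

Compound 4 `Cc1cc(Nc2ccn(Cc3ccccc3)n2)n2nc(SCc3ccc(Br)cc3)nc2n1` differs from compound 2 in one place: hydrogen in place of methyl on an aromatic carbon. The measured step from compound 1 to compound 3 concerns a different group at a different position and does not bear on this change. For the measured compounds named here, with no step in the data addressing a methyl on this six-membered aromatic ring, no change beyond the scatter is expected, and compound 2 itself offers only a limit as a starting point. Compound 4 is therefore expected to sit near the same limit, estimated at 50000 nM (range 15000 nM to 150000 nM), a step of a number no higher from compound 2 to compound 4 (the limit leaves the size open).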

Compound 4, half-maximal inhibitory concentration: > 50000 nM
Compound 4: only a limit was reported; the forecaster's own chance of this, stated with the estimate: 75%; the middle value sits exactly at the limit.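

Compound 2 and compound 4 both stand at a limit and not at a number, so no step can be read between them in this assay: the limit of > 50000 nM in this assay, at which 3 of the 4 values shown sit.

The compounds shown leave open whether 4-methylbenzyl and benzyl differ at all on this read-out.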